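Swapping the aryl group on a urea: compound 3

The source may report more compounds than this note shows. Statements on the series, on what has been measured and on what is new or still open speak of the compounds shown alone.

Measured so far:
compound 1 `Cc1ccc(NC(=O)Nc2cccc(CNc3nccnc3Cl)c2)cc1Cl` gives 11300 nM
compound 2 `CC(C)(C)c1ccc(NC(=O)Nc2cccc(CNc3nccnc3Cl)c2)cc1` gives 7550 nM

In a functional assay on HepG2 cells (Homo sapiens) for antiproliferative activity, read by MTT assay, with a stated time of 48 h (a lower number here means a stronger inhibitor, a higher number a weaker inhibitor), compound 1 gives the higher of the two numbers, yet compound 2 lies within the usual scatter of it, so the two cannot be told apart. Compound 3 `Cc1ccccc1NC(=O)Nc1cccc(CNc2nccnc2Cl)c1` is made from compound 1 by 2-methylphenyl in place of 3-chloro-4-methylphenyl on an amide-type nitrogen. Among the measured compounds shown here, no measured pair carries this change, so only the scatter of the two known values guides the expectation. The step of a 1.2-fold higher number from compound 1 to compound 3 (0.09 log units; within the scatter) is expected to be small, with no clear direction beyond the scatter. Compound 3 is therefore estimated at 14000 nM, from 5000 nM to 40000 nM.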

Compound 3, half-maximal inhibitory concentration: 15300 nM
Estimate against measurement, compound 3: 1.1-fold (0.04 log units) below, within the range that was stated.
By their numbers in this assay, from the lowest: compounds 2, 1 and 3 (each within the scatter of the next, the first and the last beyond it).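

In this assay, putting 2-methylphenyl in place of 3-chloro-4-methylphenyl on the amide-type nitrogen gives a 1.4-fold higher number from compound 1 to compound 3 (0.13 log units; within the scatter) and so cannot be told apart from the scatter of repeated measurements. This first measured step at this position shows that these two aryl groups, one with chlorine and one without, read alike here. On these data alone, whether an aryl group carrying a carboxylic acid or an amine would move the number beyond the scatter stays open. Nothing measured here offers an explanation for this result.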